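From 2-chlorophenyl to thiophen-2-yl: one open value

The source may report more compounds than this note shows. Statements on the series, on what has been measured and on what is new or still open speak of the compounds shown alone.

Compound 1 `CC(C)(C)n1ncc(OCc2nnc(-c3ccccc3Cl)o2)c(Cl)c1=O`: 61.2 ug/mL
Compound 2 `CCCCn1ncc(OCc2nnc(-c3ccccc3)o2)c(Cl)c1=O`: > 300 ug/mL

Within the data shown here, in a functional assay on the whole organism for inhibition, with Mythimna separata as the target, with a stated time of 5 days (on this read-out higher numbers stand for an effect only at larger amounts of compound and lower numbers for an effect already at smaller amounts), compound 1 gives 61.2 ug/mL, the only exact number so far. Compound 2 reads > 300 ug/mL in this assay, which is a limit and not a number. Compound 3 `CC(C)(C)n1ncc(OCc2nnc(-c3cccs3)o2)c(Cl)c1=O` has thiophen-2-yl in place of 2-chlorophenyl on an aromatic carbon. Among the measured compounds shown here, no measured pair shows this swap, so the expectation starts from compound 1 at 61.2 ug/mL alone. A modest loss is expected, an estimated 1.6-fold higher number from compound 1 to compound 3 (0.21 log units; within the scatter). The estimate for compound 3 is 100 ug/mL, with an expected range from 35 ug/mL to 300 ug/mL.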

Compound 3, half-maximal effective concentration: > 300 ug/mL
Compound 3 gave a limit, no number; the forecaster's own chance of this, stated with the estimate: 25%; middle value at least 3.0-fold (0.47 log units) away from the limit.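

Among these compounds, this is the first direct test of this position: with the rest of compound 1 unchanged, thiophen-2-yl in place of 2-chlorophenyl gives an at least 4.9-fold higher number from compound 1 to compound 3 (0.69 log units; beyond the scatter) in this assay. The group on this aromatic carbon therefore matters, and this swap loses activity beyond the usual scatter. The full size of the loss stays unknown because compound 3 reads only as a limit: the limit of > 300 ug/mL in this assay, at which 2 of the 3 values shown sit.

The compounds shown leave open whether the chlorine or the six-membered ring counts for more here. On these data alone, how a 2-methoxyphenyl or pyridin-2-yl group would read on the core of compound 1 also remains open.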